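Swapping cyclopropyl for hydroxy in compound 2

This account rests on a few compounds, and the source may have more. Where it says the series, first, only, none or still open, it means among the compounds named here.

Compound 2 `CCOc1ccc(C2C(C3CC3)C(=O)N2c2cc(OC)c(OC)c(OC)c2)cc1` gives 201 nM in a functional assay on HL-60 cells (Homo sapiens) for inhibition, read by resazurin assay, with a stated time of 72 h; on this read-out higher numbers stand for weaker inhibition and lower numbers for stronger inhibition. That places it at the weak end of the three measured values, level with compound 3 `COc1ccc(C2C(C3CC3)C(=O)N2c2cc(OC)c(OC)c(OC)c2)cc1` at 156 nM. Compound 4 `CCOc1ccc(C2C(O)C(=O)N2c2cc(OC)c(OC)c(OC)c2)cc1` puts hydroxy in place of cyclopropyl on a saturated ring carbon. Among the measured compounds shown here, no measured step makes this exact change. For the measured compounds named here, the one step available, a 1.3-fold lower number from compound 2 to compound 3 (0.11 log units; within the scatter), alters the ethoxy group instead and stays within the scatter. The closest guide carries the hydroxy and has sulfur where compound 4 has the ethoxy oxygen: compound 1 `CCSc1ccc(C2C(O)C(=O)N2c2cc(OC)c(OC)c(OC)c2)cc1` gives 16 nM. A large step to a lower number, beyond the scatter, is therefore expected in this assay: an 8.0-fold lower number from compound 2 to compound 4 (0.91 log units; beyond the scatter). Compound 4 is estimated at 25 nM, within a range of 8 nM to 80 nM.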

Compound 4, half-maximal inhibitory concentration: 11 nM
For compound 4 the middle estimate is 2.3-fold (0.36 log units) above the measured one; low and high end bracket the measured number.
By their numbers in this assay, from the lowest: compounds 4 and 1 (each within the scatter of the next); then compounds 3 and 2 (each within the scatter of the next).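

Hydroxy in place of cyclopropyl on this saturated ring carbon can now be read directly in this assay, and the change gives much stronger inhibition (an 18-fold lower number from compound 2 to compound 4 (1.26 log units; beyond the scatter)). With the hydroxy kept, ethoxy in place of ethylsulfanyl on the aromatic carbon stays within the scatter (a 1.5-fold lower number from compound 1 to compound 4 (0.16 log units; within the scatter)), so compound 4 and compound 1 read alike. The hydroxy on this ring carbon therefore goes with strong inhibition alongside either group on the aromatic ring.

As far as these compounds go, whether an amine, a fluorine or a longer chain on this ring carbon would match hydroxy remains open. Nothing available explains the size of the hydroxy step.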